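Anilide variation on a shared indole azo benzamide core

The source may hold more compounds than are shown below. What is called first, only, known or untested is meant among the compounds shown, and "the series" means these compounds.

Measured so far in a functional assay on HCT-116 cells (Homo sapiens) for inhibition, read by MTT assay, with a stated time of 72 h; a lower number here means a stronger inhibitor, a higher number a weaker inhibitor:
compound 1 `O=C(Nc1ccccc1)c1ccc(/N=N\c2c[nH]c3ccccc23)cc1` — 103000 nM
compound 2 `O=C(Nc1ccccc1[N+](=O)[O-])c1ccc(/N=N\c2c[nH]c3ccccc23)cc1` — 208000 nM
compound 3 `O=C(Nc1ccccc1Cl)c1ccc(/N=N\c2c[nH]c3ccccc23)cc1` — 120000 nM

Compound 3 stands second highest of the three numbers, close to compound 1 and further from compound 2, both gaps within the scatter. Compound 4 `Cc1ccc(C)c(NC(=O)c2ccc(/N=N\c3c[nH]c4ccccc34)cc2)c1` carries 2,5-dimethylphenyl in place of 2-chlorophenyl on an amide-type nitrogen. Among the compounds with values here, the steps that bear on this are a 1.2-fold higher number from compound 1 to compound 3 (0.07 log units; within the scatter) and a 2.0-fold higher number from compound 1 to compound 2 (0.31 log units; beyond the scatter), and between the two substituted anilides a 1.7-fold lower number from compound 2 to compound 3 (0.24 log units; within the scatter); only the nitro step reaches beyond the scatter, and it is modest. Since both substituted anilides stay near the unsubstituted compound 1, a dimethyl pattern is expected to give no step beyond the scatter, no change at the digits printed from compound 3 to compound 4 (within the scatter). Compound 4 is therefore estimated at 120000 nM, within 55000 nM to 260000 nM.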

Compound 4, half-maximal inhibitory concentration: 544000 nM
Compound 4: middle estimate off by 4.5-fold (0.66 log units), on the low side, and the stated range ends below it.
By their numbers in this assay, from the lowest: compounds 1, 3 and 2 (each within the scatter of the next, the first and the last beyond it); then compound 4.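

In this assay 2,5-dimethylphenyl on the amide-type nitrogen gives a 5.3-fold higher number from compound 1 to compound 4 (0.72 log units; beyond the scatter) and also a 4.5-fold higher number from compound 3 to compound 4 (0.66 log units; beyond the scatter) and a 2.6-fold higher number from compound 2 to compound 4 (0.42 log units; beyond the scatter) so compound 4 stands beyond the scatter of all three others, with the highest number of the four. Chloro had stayed within the scatter of compound 1, so this position does not respond alike to every anilide change. No evidence at hand bears on this result. Which of the two methyl groups carries the step remains open. So does how an amine or a carboxylic acid on the phenyl ring would read here.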